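Chloro for Methyl on the Benzylidene Ring

This account rests on a few compounds, and the source may have more. Where it says the series, first, only, none or still open, it means among the compounds named here.

Measured so far:
- compound 1 `COc1ccc(/C=C2\CCc3cc(OC)c(OC)cc3C2=O)c(OC)c1`: > 50000 nM
- compound 2 `COc1cc2c(cc1OC)C(=O)/C(=C/c1cc(C)c(O)c(C)c1)CC2`: 4800 nM
- compound 3 `COc1cc2c(cc1OC)C(=O)/C(=C/c1cccc(C)c1)C2`: 1800 nM

In a functional assay on Jurkat cells (Homo sapiens) for antiproliferative activity, read by MTT assay (on this read-out higher numbers stand for weaker inhibition and lower numbers for stronger inhibition), compound 1 gives > 50000 nM, which is a limit of the assay and not a number, as noted in the limit of > 50000 nM in this assay, at which 1 of the 3 values shown sits. Compound 2 gives 4800 nM in this assay. Compound 3 gives 1800 nM, the lowest of the two numbers shown; its nearest neighbour is compound 2, whose number is higher by a gap beyond the usual scatter.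

Compound 4 `COc1cc2c(cc1OC)C(=O)/C(=C/c1cccc(Cl)c1)C2` has not yet been measured. It differs from compound 3 by chloro in place of methyl on an aromatic carbon, in words a chloro in place of a methyl on an aromatic carbon. Within the data shown here, no measured pair in this set shows the same change, so the expectation rests on compound 3 alone. Chloro and methyl are both single heavy atoms without donors or acceptors, so the step is expected to be small, in either direction or within the scatter. Compound 4 is estimated at 1500 nM, between 500 nM and 5000 nM, an expected step of a 1.2-fold lower number from compound 3 to compound 4 (0.08 log units; within the scatter).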

Compound 4, half-maximal inhibitory concentration: 8000 nM
For compound 4 the middle estimate is 5.3-fold (0.73 log units) below the measured one; the measured number lies above the stated range.
By their numbers in this assay, from the lowest: compound 3; then compounds 2 and 4 (each within the scatter of the next). At a limit, above all of these: compound 1.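

Methyl and chloro match in heavy-atom count and neither carries a hydrogen-bond donor or acceptor, yet they are not interchangeable at this place: in this assay, going from 3-methylphenyl to 3-chlorophenyl brings a 4.4-fold higher number from compound 3 to compound 4 (0.65 log units; beyond the scatter), which means weaker inhibition. Among these compounds, the earlier compounds offered no pair differing in one place, so this is the first direct reading of a single change in the set, and it shows that inhibition responds to which group sits on this aromatic carbon, with methyl the better of the two. Nothing measured here accounts for the step.

The compounds shown leave open how an amine or a carboxylic acid on this carbon would read out. Going by these compounds, whether the same swap gives a similar step on the core of compound 2 also remains unknown.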